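The compounds below may be only part of what the source reports. "The series", "measured", "known", "first", "only" and "open" are said of these compounds alone.

Measured compounds:
compound 1, `CC(C)/N=C(\NC1=NC(=O)CN1C(C)C)Nc1ccc(Cl)c(Cl)c1`, 0.883 h
compound 2, `CC(C)/N=C(\NC1=NC(=O)CN1C)Nc1ccc(Cl)c(Cl)c1`, > 1 h (a limit of the assay, not a number)
compound 3, `CCC(CC)C(=O)/N=C(\NC1=NC(=O)CN1C(C)C)Nc1ccc(Cl)c(Cl)c1`, 0.233 h

In an in vivo ADME assay on the whole organism for metabolic stability, with Homo sapiens as the target, read by LC-MS, at a dose of 320 mg/kg by the oral route (a lower number here means that the compound disappears faster, a higher number that the compound lasts longer), compound 3 holds the lowest of the two numbers; the nearest is compound 1, reached by a 3.8-fold lower number from compound 1 to compound 3 (0.58 log units; beyond the scatter). Compound 2 reports only a limit, (the limit of > 1 h in this assay, at which 1 of the 3 values shown sits).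

Compound 4, `CCOC(=O)/N=C(\NC1=NC(=O)CN1C(C)C)Nc1ccc(Cl)c(Cl)c1`, differs from compound 3 by ethoxy in place of pentan-3-yl on a carbonyl carbon. Going by the values given here, the only measured step touching this nitrogen is a 3.8-fold lower number from compound 1 to compound 3 (0.58 log units; beyond the scatter), which exchanged an alkyl for an acyl group; compound 4 keeps the carbonyl and alters only what sits on it. Among the compounds with values here, no measured step compares two such acyl groups, so a step in this assay no larger than the scatter is expected, in no firm direction. Compound 4 is therefore estimated at 0.3 h (0.15 h to 0.7 h), an expected step of a 1.3-fold higher number from compound 3 to compound 4 (0.11 log units; within the scatter).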

Compound 4, half-life: 0.572 h
Compound 4: middle estimate off by 1.9-fold (0.28 log units), on the low side; the range from low to high includes it.
By their numbers in this assay, from the lowest: compound 3; then compounds 4 and 1 (each within the scatter of the next). At a limit, above all of these: compound 2.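

In this assay, what sits on the carbonyl carbon counts by itself: ethoxy in place of pentan-3-yl gives a 2.5-fold higher number from compound 3 to compound 4 (0.39 log units; beyond the scatter) with the carbonyl kept. Ethoxycarbonyl in place of isopropyl on the double-bonded nitrogen gives a 1.5-fold lower number from compound 1 to compound 4 (0.19 log units; within the scatter) and stays within the scatter, so a carbonyl there does not by itself bring the drop seen with (pentan-3-yl)carbonyl. Nothing measured here explains either step.

On these data alone, it stays open whether an amine or a longer alkoxy chain on that carbonyl carbon would read like ethoxy or like pentan-3-yl.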